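Swapping chloro for hydroxy on the aromatic carbon

The compounds below may be only part of what the source reports. "The series", "measured", "known", "first", "only" and "open" are said of these compounds alone.

Measured in a functional assay on B16 cells (Mus musculus) for inhibition; on this read-out higher numbers stand for weaker inhibition and lower numbers for stronger inhibition:
- Compound 1 `CCc1ccccc1/C=N/NC(N)=S`: 2700 nM
- Compound 2 `NC(=S)N/N=C/c1ccccc1Cl`: 1400 nM

Compound 2, at 1400 nM, sits within the usual scatter of compound 1, so these two cannot be told apart. Compound 3 `NC(=S)N/N=C/c1ccccc1O` has not been measured yet and differs from compound 2 in one place: hydroxy in place of chloro on an aromatic carbon. Among the measured compounds shown here, the one measured step that bears on this change is a 1.9-fold lower number from compound 1 to compound 2 (0.29 log units; within the scatter), with chloro in place of ethyl on an aromatic carbon. For the measured compounds named here, no hydroxy compound has been measured, so that small step is only a weak guide, and no change beyond the scatter is expected in this assay. The expected step is a 1.1-fold higher number from compound 2 to compound 3 (0.03 log units; within the scatter). For compound 3 the estimated value is 1500 nM, with an expected range of 500 nM to 4500 nM.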

Compound 3, half-maximal inhibitory concentration: 21000 nM
Beside the measured number, compound 3's estimate is 14-fold (1.15 log units) below it, outside the stated range (above it).
By their numbers in this assay, from the lowest: compounds 2 and 1 (each within the scatter of the next); then compound 3.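

In this assay, chloro and ethyl could not be told apart, but hydroxy separates clearly from both, with a 15-fold higher number from compound 2 to compound 3 (1.18 log units; beyond the scatter) and a 7.8-fold higher number from compound 1 to compound 3 (0.89 log units; beyond the scatter) on the scale where higher means weaker inhibition. So this position is not indifferent to what sits on it: exchanging one heavy atom for another is enough to weaken inhibition. Nothing available explains why the hydroxy compound behaves differently.

Going by these compounds, whether this loss is specific to hydroxy remains open. An amine or a methoxy group at the same position could show whether other groups carrying oxygen or nitrogen also weaken inhibition.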